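Aryl urea series: hydrogen in place of chloro

This account rests on a few compounds, and the source may have more. Where it says the series, first, only, none or still open, it means among the compounds named here.

Three measured compounds share one core. Compound 1 `COc1ccc(NC(=O)Nc2nc(Sc3c[nH]c4ccccc34)cc(N3CCN(c4ccccn4)CC3)n2)cc1` is tested in a functional assay on PC-3 cells (Homo sapiens) for inhibition, with a stated time of 72 h (on this read-out higher numbers stand for weaker inhibition and lower numbers for stronger inhibition), and gives 33400 nM. Compound 2 `O=C(Nc1ccccc1)Nc1nc(NC2CC2)cc(Sc2c[nH]c3ccccc23)n1` gives 17500 nM in this assay. Compound 3 `O=C(Nc1ccc(Cl)cc1)Nc1nc(Sc2c[nH]c3ccccc23)cc(N2CCCC2)n1` gives 10400 nM in this assay, the lowest of the three numbers; its value and that of compound 2 lie within the scatter of each other, while the gap to compound 1 lies beyond it. Compound 4 `O=C(Nc1ccccc1)Nc1nc(Sc2c[nH]c3ccccc23)cc(N2CCCC2)n1` differs from compound 3 by hydrogen in place of chloro on an aromatic carbon. Among the compounds with values here, no measured pair shows this change on its own; the expectation is a small step toward a higher number, or none beyond the scatter, estimated as a 1.4-fold higher number from compound 3 to compound 4 (0.16 log units; within the scatter). Compound 4 is expected to give about 15000 nM in this assay, within 6000 nM to 40000 nM.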

Compound 4, half-maximal inhibitory concentration: 14900 nM
Compound 4: middle estimate off by 1.0-fold (0.00 log units), on the high side, within the range that was stated.
By their numbers in this assay, from the lowest: compounds 3, 4, 2 and 1 (each within the scatter of the next, the first and the last beyond it).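

In this assay, hydrogen in place of chloro gives a 1.4-fold higher number from compound 3 to compound 4 (0.16 log units; within the scatter), so on this aromatic carbon the change from 4-chlorophenyl to phenyl cannot be told from the scatter. With phenyl held constant, pyrrolidin-1-yl in place of cyclopropylamino gives a 1.2-fold lower number from compound 2 to compound 4 (0.07 log units; within the scatter), which likewise cannot be told from the scatter. No available data bear on a cause for either step.

Still open, as far as these compounds go, is whether a trifluoromethyl or a carboxylic acid in place of chloro on this aromatic carbon would give a step beyond the scatter.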